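Diaryl urea series: ethoxy for trifluoromethyl, solubility outlook

The source may hold more compounds than are shown below. What is called first, only, known or untested is meant among the compounds shown, and "the series" means these compounds.

In a physicochemical assay for solubility, read by HPLC, with a stated time of 4 h, at pH 7 (on this read-out lower numbers stand for lower solubility and higher numbers for higher solubility), compound 2 `C[C@]1(COc2ccc(NC(=O)Nc3ccc(C(F)(F)F)cc3)cc2)Cn2cc([N+](=O)[O-])nc2O1` gives < 1 ug/mL, which is a limit of the assay rather than a number. Compound 1 `CCc1ccc(NC(=O)Nc2ccc(OC[C@@]3(C)Cn4cc([N+](=O)[O-])nc4O3)cc2)cc1` gives < 1 ug/mL, likewise a limit. The step that the two limits leave unreadable from compound 1 to compound 2 is therefore unreadable, and the limit of < 1 ug/mL in this assay, at which 2 of the 2 values shown sit, is all that the measured pair offers. Compound 3 `CCOc1ccc(NC(=O)Nc2ccc(OC[C@@]3(C)Cn4cc([N+](=O)[O-])nc4O3)cc2)cc1` differs from compound 2 by ethoxy in place of trifluoromethyl on an aromatic carbon. For the measured compounds named here, no measured step covers this change, and the single measured step has no readable size, so nothing beyond the scatter is expected. The expected step of a number no lower from compound 2 to compound 3 (the limit leaves the size open) is accordingly small. Compound 3 is estimated at 1 ug/mL, range 0.3 ug/mL to 4 ug/mL, with a real chance of again only a limit.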

Compound 3, solubility: 6.66 ug/mL
Beside the measured number, compound 3's estimate is 6.7-fold (0.82 log units) below it; measured number outside the range, above it.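

In this assay, this aromatic carbon, para to a large group, now shows a readable dependence on its substituent: ethoxy in place of trifluoromethyl gives an at least 6.6-fold higher number from compound 2 to compound 3 (0.82 log units; beyond the scatter), and ethoxy in place of ethyl gives an at least 6.6-fold higher number from compound 1 to compound 3 (0.82 log units; beyond the scatter). The step between the ethyl and trifluoromethyl compounds still cannot be read, so only ethoxy stands apart from the other two. Both readable steps are minimum sizes, as each starts from a limit: the limit of < 1 ug/mL in this assay, at which 2 of the 3 values shown sit.

Going by these compounds, how far the rise extends remains open, since the true values of compound 1 and compound 2 are unknown. Also open, on these data alone, is how methoxy, a longer alkoxy chain or a dimethylamino group would read at this carbon.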